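The source may hold more compounds than are shown below. What is called first, only, known or untested is meant among the compounds shown, and "the series" means these compounds.

Three amides of the shared core have been measured in a functional assay on HepG2 cells (Homo sapiens), read by MTT assay, with a stated time of 48 h; a higher number here means a weaker inhibitor, a lower number a stronger inhibitor. Compound 1 `CCn1c(C(=O)NCCN(C)C)ccc1C(CC)(CC)c1ccc(OCC(O)C(C)(C)C)c(C)c1` gives 870 nM, compound 2 `CCn1c(C(=O)NCCCN(C)C)ccc1C(CC)(CC)c1ccc(OCC(O)C(C)(C)C)c(C)c1` gives 360 nM, and compound 3 `CCn1c(C(=O)NCC(OC)OC)ccc1C(CC)(CC)c1ccc(OCC(O)C(C)(C)C)c(C)c1` gives 23200 nM, the highest of the three numbers, with its gaps to both others beyond the scatter.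

Compound 4 `CCn1c(C(=O)N(C)CCC#N)ccc1C(CC)(CC)c1ccc(OCC(O)C(C)(C)C)c(C)c1` differs from compound 3 as follows: (2-cyanoethyl)(methyl)amino in place of (2,2-dimethoxyethyl)amino on a carbonyl carbon. In short, (2-cyanoethyl)(methyl)amino stands in place of (2,2-dimethoxyethyl)amino on a carbonyl carbon.

Two large steps bear on this change: a 27-fold higher number from compound 1 to compound 3 (1.43 log units; beyond the scatter) and a 64-fold higher number from compound 2 to compound 3 (1.81 log units; beyond the scatter). Both remove a dimethylamino end, and compound 4 has no such end either, so no return towards the lower numbers is expected. Among the chains ending in dimethylamino, a 2.4-fold lower number from compound 1 to compound 2 (0.38 log units; beyond the scatter) is only modest. Within the data shown here, no measured compound carries a nitrile, so the range stays wide.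

The expected step is a 1.5-fold lower number from compound 3 to compound 4 (0.16 log units; within the scatter), which would not go beyond the scatter. For compound 4 the estimate is 16000 nM, with an expected range of 5000 nM to 45000 nM.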

Compound 4, half-maximal inhibitory concentration: > 50000 nM
Compound 4 was reported as a limit; the forecaster's own chance of this, stated with the estimate: 12%; middle value at least 3.1-fold (0.49 log units) away from the limit.
By their numbers in this assay, from the lowest: compound 2; then compound 1; then compound 3. At a limit, above all of these: compound 4.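

In this assay, compound 4 is reported only as a limit, not as a number: the limit of > 50000 nM in this assay, at which 1 of the 4 values shown sits. Even without a dimethylamino end the group on the carbonyl carbon still moves the read-out, with an at least 2.1-fold higher number from compound 3 to compound 4 (0.33 log units; beyond the scatter), so compound 3 does not mark the weak end of this position. Against the chains ending in dimethylamino the gaps are an at least 130-fold higher number from compound 2 to compound 4 (2.14 log units; beyond the scatter) and an at least 57-fold higher number from compound 1 to compound 4 (1.75 log units; beyond the scatter), and all three steps are bounds, not exact sizes.

This change removes the amide hydrogen and brings in the nitrile together, and the compounds shown do not separate the two. A (2-cyanoethyl)amino group, which keeps the amide hydrogen, and a (3-(dimethylamino)propyl)(methyl)amino group would address that, while a longer chain ending in dimethylamino remains an open question for the lower numbers.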